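Formyl in place of amino: notes on the next step

The source may hold more compounds than are shown below. What is called first, only, known or untested is meant among the compounds shown, and "the series" means these compounds.

Measured in a functional assay on MCF7 cells (Homo sapiens) for antiproliferative activity, read by WST assay, with a stated time of 3 days; a lower number here means a stronger inhibitor, a higher number a weaker inhibitor:
compound 1 `O=Cc1cc(=O)[nH]c(=O)n1[C@@H]1O[C@H](CO)[C@@H](O)[C@H]1O`: > 50000 nM (a limit)
compound 2 `[N-]=[N+]=Nc1c(F)c(=O)[nH]c(=O)n1[C@@H]1O[C@H](CO)[C@@H](O)[C@H]1O`: 1000 nM
compound 3 `Nc1c(F)c(=O)[nH]c(=O)n1[C@@H]1O[C@H](CO)[C@@H](O)[C@H]1O`: 1400 nM

Compound 3 gives 1400 nM and lies within the scatter of compound 2, so the two cannot be ranked. For the measured compounds named here, these are the only two true numbers so far. Compound 4 `O=Cc1c(F)c(=O)[nH]c(=O)n1[C@@H]1O[C@H](CO)[C@@H](O)[C@H]1O` is the next compound to consider, with formyl in place of amino on an aromatic carbon, ortho to a fluoro group: formyl in place of amino on an aromatic carbon.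

Going by the values given here, one measured step touches the same carbon: a 1.4-fold higher number from compound 2 to compound 3 (0.15 log units; within the scatter). This exchange of amino for azido gives no shift beyond the scatter, but it does not involve formyl. Among the compounds with values here, compound 1 , the only measured compound with a formyl group, reports only a limit, > 50000 nM, so some loss of activity is expected for compound 4 rather than no change at all.

The expected move in this assay is a 2.9-fold higher number from compound 3 to compound 4 (0.46 log units; beyond the scatter), toward a higher number and thus a weaker inhibitor. With so little evidence, the expected range is wide. For compound 4 the estimated value is 4000 nM, expected to fall between 700 nM and 30000 nM.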

Compound 4, half-maximal inhibitory concentration: 23700 nM
Estimate against measurement, compound 4: 5.9-fold (0.77 log units) below, and the stated range covers the measured number.
By their numbers in this assay, from the lowest: compounds 2 and 3 (each within the scatter of the next); then compound 4. At a limit, above all of these: compound 1.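

In this assay, the carbon ortho to a fluoro group proves sensitive to its substituent: compound 2 and compound 3 could not be ranked, but formyl gives a 17-fold higher number from compound 3 to compound 4 (1.23 log units; beyond the scatter) and a 24-fold higher number from compound 2 to compound 4 (1.37 log units; beyond the scatter). The earlier pair therefore showed only that azido and amino sit within the scatter of each other, whereas this result shows that the position does not accept every group alike, at least among the three groups seen here. With formyl held in place, fluoro in place of hydrogen gives an at least 2.1-fold lower number from compound 1 to compound 4 (0.32 log units; beyond the scatter), and the size of this step is only a bound since compound 1 stands at a limit: the limit of > 50000 nM in this assay, at which 1 of the 4 values shown sits.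

Going by these compounds, whether the loss belongs to formyl alone or extends to a hydroxymethyl, a methyl or a carboxylic acid on this carbon remains open. Also open, on these data alone, is how far the fluoro group matters when amino or azido occupies that carbon, and whether chloro could take the place of fluoro.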